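Benzyl in place of methyl on the saturated ring carbon

The compounds below may be only part of what the source reports. "The series", "measured", "known", "first", "only" and "open" are said of these compounds alone.

Compound 3 `CC1Sc2nnc(-c3[nH]nc4c3CCC4)n2N=C1c1ccc(Cl)c(Cl)c1` gives 1900 nM in a functional assay on CAL-33 cells (Homo sapiens) for inhibition (on this read-out higher numbers stand for weaker inhibition of growth and lower numbers for stronger inhibition of growth), the second highest of the three numbers measured. Compound 1 `CC(C)C1Sc2nnc(-c3[nH]nc4c3CCC4)n2N=C1c1ccc(Cl)c(Cl)c1` gives 8200 nM. Compound 2 `COCCC1Sc2nnc(-c3cc(-c4ccccc4)n[nH]3)n2N=C1c1ccc(OC)cc1` differs from compound 3 in several places at once, and compound 2 gives 40 nM. Among the compounds with values here, the one single-site step recorded is a 4.3-fold lower number from compound 1 to compound 3 (0.64 log units; beyond the scatter), so the larger group on that saturated ring carbon went with the higher number. Compound 4 `Clc1ccc(C2=Nn3c(nnc3-c3[nH]nc4c3CCC4)SC2Cc2ccccc2)cc1Cl` carries phenyl in place of hydrogen on a saturated chain carbon bound to a saturated ring carbon. Within the data shown here, only the step from compound 1 to compound 3 bears on this change, and it points toward a higher number for this change, so a modest rise in this assay is expected, though compound 2 shows that a different chain at this carbon can sit with a low number. Compound 4 is estimated at 4500 nM, within 1500 nM to 15000 nM, a step of a 2.4-fold higher number from compound 3 to compound 4 (0.37 log units; beyond the scatter).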

Compound 4, concentration for 50% growth inhibition: 3300 nM
Beside the measured number, compound 4's estimate is 1.4-fold (0.13 log units) above it; the measured number falls inside the stated range.
By their numbers in this assay, from the lowest: compound 2; then compounds 3 and 4 (each within the scatter of the next); then compound 1.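

In this assay, a 1.7-fold higher number from compound 3 to compound 4 (0.24 log units; within the scatter) leaves benzyl and methyl on the saturated ring carbon unseparated, while a 2.5-fold lower number from compound 1 to compound 4 (0.40 log units; beyond the scatter) sets benzyl apart from isopropyl. The earlier reading, that the larger group at this carbon goes with the higher number, therefore does not extend across the series: compound 4 goes against it. No evidence here bears on the reason for this result.

On these data alone, compound 2 gives 40 nM but differs from compound 3 in several places, so the share of its chain remains open. As far as these compounds go, how an amine or a carboxylic acid at this carbon would read also remains open.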